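The compounds below may be only part of what the source reports. "The series", "measured", "known", "first", "only" and "open" are said of these compounds alone.

In a functional assay on MV4-11 cells (Homo sapiens) for cytotoxicity, read by MTT assay, with a stated time of 72 h (a lower number here means a stronger inhibitor, a higher number a weaker inhibitor), compound 1 (`CCOC(=O)c1csc2nc(-c3cccc(NC(=O)c4ccco4)c3)cn12`) gives > 20000 nM, which is a limit of the assay and not a number. Compound 2 (`CCCS(=O)(=O)Nc1ccc(-c2cn3c(C(=O)OCC)csc3n2)cc1`) gives > 20000 nM, likewise only a limit. Compound 2 therefore stands at the limit of > 20000 nM in this assay, at which 2 of the 2 values shown sit, with no number to start from. Compound 3 (`C=CC(=O)Nc1ccc(-c2cn3c(C(=O)OCC)csc3n2)cc1`) carries vinylcarbonyl in place of propylsulfonyl on a nitrogen on an aromatic ring. For the measured compounds named here, no measured step shows what such a change does. Only a modest gain in strength is expected, an at least 1.4-fold lower number from compound 2 to compound 3 (0.15 log units; that floor lies within the scatter), and the reading may well remain a limit. For compound 3 the estimated value is 14000 nM, within an expected range of 3000 nM to 40000 nM.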

Compound 3, half-maximal inhibitory concentration: 2930 nM
Beside the measured number, compound 3's estimate is 4.8-fold (0.68 log units) above it; the measured number lies below the stated range.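

In this assay, a nitrogen on an aromatic ring proves to be a place where one change brings a reading off the limit: vinylcarbonyl in place of propylsulfonyl gives an at least 6.8-fold lower number from compound 2 to compound 3 (0.83 log units; beyond the scatter). The shared core can therefore give a measured number in this assay when it carries the right group at this place. The true size of the step stays unknown because compound 2 gives only a limit of the assay: the limit of > 20000 nM in this assay, at which 2 of the 3 values shown sit.

Left open is whether the gain follows the carbonyl or the vinyl end of the new group. A saturated propanoyl group on the same nitrogen would separate the two.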